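Mirror-image cyclopropane-fused core of compound 2

This account rests on a few compounds, and the source may have more. Where it says the series, first, only, none or still open, it means among the compounds named here.

Compound 1 `O=C(NC1(c2ccc3c(n2)CCN3C(=O)OC2CC2)CC1)c1ccc(Cl)cc1` and compound 2 `COC(=O)N1c2ccc(C3(NC(=O)c4ccc(F)cc4)CC3)cc2[C@@H]2CC[C@@H]21` share the amide-bearing cyclopropyl motif and a carbamate on the ring nitrogen. In an assay on HeLa cells for inhibition of Indoleamine 2,3-dioxygenase 1 (Homo sapiens) (on this read-out lower numbers stand for stronger inhibition and higher numbers for weaker inhibition), compound 1 gives 4.1 nM. In this assay compound 2 gives 5.6 nM; the two values lie within the usual scatter of each other, so neither stands apart. Compound 3 `COC(=O)N1c2ccc(C3(NC(=O)c4ccc(F)cc4)CC3)cc2[C@H]2CC[C@H]21` is the mirror image of compound 2: the two compounds have the same atoms and bonds and differ only in configuration as drawn: 2 of 2 stereo elements differ (all stereocentres are inverted: mirror images); a stereocentre at a saturated ring carbon is drawn S in compound 2 and R in compound 3; a stereocentre at a saturated ring carbon is drawn S in compound 2 and R in compound 3. For the measured compounds named here, no measured pair shows what inverting both stereocentres does here, so the size and even the direction of the step are open. For an enantiomer the step from compound 2 is expected to be a 3.6-fold higher number from compound 2 to compound 3 (0.55 log units; beyond the scatter), with a wide range on either side. Compound 3 is accordingly estimated at 20 nM, between 4 nM and 200 nM.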

Compound 3, half-maximal inhibitory concentration: 2.8 nM
Beside the measured number, compound 3's estimate is 7.1-fold (0.85 log units) above it; the measured number lies below the stated range.
By their numbers in this assay, from the lowest: compounds 3, 1 and 2 (each within the scatter of the next).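

In this assay, inverting both stereocentres of the shared core gives a 2.0-fold lower number from compound 2 to compound 3 (0.30 log units; within the scatter), so this pair of mirror images is not separated on this read-out. The earlier compounds shown here offered no comparison of configuration at these saturated ring carbons; this pair shows that either drawn configuration keeps the number within the scatter, at least with this carbamate and this fluorinated amide in place. The comparison isolates configuration alone, with no other change in the structure to take into account: the fact that compounds 2 and 3 differ only in the configuration as drawn.

The compounds shown leave open what inverting only one of the two stereocentres would do. They also leave open whether the two configurations would stay this close with an amine or a carboxylic acid in place of the carbamate or the fluorine.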